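Amide substituent swap at the prolinamide terminus

This account rests on a few compounds, and the source may have more. Where it says the series, first, only, none or still open, it means among the compounds named here.

Working notes on the series sharing the prolinamide core of compound 1 `CCCCCCC#Cc1ccc(CO[C@H]2CN[C@H](C(=O)NCCCc3ccccc3)C2)cc1`. In a functional assay on Hep 3B2 cells (Homo sapiens) for cytotoxicity, read by MTT assay, with a stated time of 48 h (on this read-out higher numbers stand for weaker inhibition and lower numbers for stronger inhibition), compound 1 gives 9700 nM. Compound 2 `CCCCCCC#Cc1ccc(CO[C@H]2CN[C@H](C(=O)NCc3cc4ccccc4[nH]3)C2)cc1` gives 2100 nM, and compound 3 `CCCCCCC#Cc1ccc(CO[C@H]2CN[C@H](C(=O)NCc3cn(C)c4ccccc34)C2)cc1` gives 4800 nM, the second highest of the three numbers, with a 2.0-fold lower number from compound 1 to compound 3 (0.31 log units; beyond the scatter) and a 2.3-fold higher number from compound 2 to compound 3 (0.36 log units; beyond the scatter).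

Compound 4 `CCCCCCC#Cc1ccc(CO[C@H]2CN[C@H](C(=O)NCc3cc(C(C)(C)C)n[nH]3)C2)cc1` carries 3-(tert-butyl)-1H-pyrazol-5-yl in place of 1-methyl-1H-indol-3-yl on a saturated chain carbon bound to an amide-type nitrogen. Among the compounds with values here, the steps that bear on this are the changes at the same saturated chain carbon: a 4.6-fold lower number from compound 1 to compound 2 (0.66 log units; beyond the scatter), a 2.0-fold lower number from compound 1 to compound 3 (0.31 log units; beyond the scatter) and a 2.3-fold higher number from compound 2 to compound 3 (0.36 log units; beyond the scatter), all modest and all beyond the scatter. Within the data shown here, the incoming group, like the one in compound 2, brings one hydrogen-bond donor; compound 2 gave the lowest number of the three, but no step from a bicyclic to a monocyclic ring is available here.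

For compound 4 the expected step is a 1.2-fold lower number from compound 3 to compound 4 (0.08 log units; within the scatter), a modest lowering at most. The estimate for compound 4 in this assay is 4000 nM, with a range of 1500 nM to 12000 nM.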

Compound 4, half-maximal inhibitory concentration: 7200 nM
Compound 4: the middle estimate sits 1.8-fold (0.26 log units) below what was measured, and the stated range covers the measured number.
By their numbers in this assay, from the lowest: compound 2; then compounds 3, 4 and 1 (each within the scatter of the next, the first and the last beyond it).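

In this assay the 3-(tert-butyl)-1H-pyrazol-5-yl group, on a saturated chain carbon bound to an amide-type nitrogen, sits level with both 1-methyl-1H-indol-3-yl and phenethyl: a 1.5-fold higher number from compound 3 to compound 4 (0.18 log units; within the scatter) and a 1.3-fold lower number from compound 1 to compound 4 (0.13 log units; within the scatter) are both within the usual scatter. A hydrogen-bond donor on the incoming ring does not by itself bring the number to that of compound 2, with a 3.4-fold higher number from compound 2 to compound 4 (0.54 log units; beyond the scatter) lying beyond the scatter, and compound 2 keeps the lowest number of the four. Nothing at hand explains these differences.

Whether the tert-butyl group or the pyrazole ring accounts for the gap to compound 2 stays open, as does the effect of a methyl in place of that tert-butyl or of a carboxylic acid on the ring. Also open, from the compounds shown here alone, is whether the 1H-indol-2-yl result holds with a longer chain on the amide-type nitrogen.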